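The compounds below may be only part of what the source reports. "The series", "measured", "known", "first", "only" and "open" are said of these compounds alone.

Measured so far in an ADME assay on A549 cells (Homo sapiens) for cytotoxicity, read by resazurin assay, with a stated time of 48 h (on this read-out lower numbers stand for higher toxicity in this test and higher numbers for lower toxicity in this test), are two compounds:

- Compound 1 `O=C(Nc1ccc(N(CC2CC2)CC2CC2)cc1Cl)c1cc(Cl)ccc1O` gives 12800 nM
- Compound 2 `O=C(Nc1ccc(NCc2ccc(Br)s2)cc1Cl)c1cc(Cl)ccc1O` gives 20700 nM

Not yet measured: compound 3 `CC(C)(CCO)Nc1ccc(NC(=O)c2cc(Cl)ccc2O)c(Cl)c1`

Compound 2 at 20700 nM lies within the scatter of compound 1, so these two values cannot be told apart. The next change puts 3-hydroxy-1,1-dimethylpropyl in place of (5-bromothiophen-2-yl)methyl on a nitrogen on an aromatic ring, and 3-hydroxy-1,1-dimethylpropyl in place of (5-bromothiophen-2-yl)methyl on a nitrogen on an aromatic ring gives the count of what is exchanged.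

Within the data shown here, only one measured step bears on this change. It is a 1.6-fold higher number from compound 1 to compound 2 (0.21 log units; within the scatter) and it shows that a different group on that nitrogen left the read-out within the scatter. Among the measured compounds shown here, that is thin evidence, since no measured compound carries the entering group. With compound 2 at 20700 nM as the starting point, no step beyond the scatter is expected. The estimated change is a 1.2-fold higher number from compound 2 to compound 3 (0.08 log units; within the scatter) and it stays small. Compound 3 is expected at 25000 nM (estimated range 9000 nM to 70000 nM).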

Compound 3, half-maximal cytotoxic concentration: 170000 nM
Compound 3: the middle estimate sits 6.8-fold (0.83 log units) below what was measured; the measured number lies above the stated range.
By their numbers in this assay, from the lowest: compounds 1 and 2 (each within the scatter of the next); then compound 3.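

In this assay, this nitrogen turns out to be a place where the group can move the number a long way: the exchange gives (an 8.2-fold higher number from compound 2 to compound 3 (0.91 log units; beyond the scatter)), and the wider comparison gives (a 13-fold higher number from compound 1 to compound 3 (1.12 log units; beyond the scatter)), both beyond the scatter, while the earlier step (a 1.6-fold higher number from compound 1 to compound 2 (0.21 log units; within the scatter)) had stayed within it. The two earlier groups therefore gave no hint of this range, and compound 3 now stands apart from both as the least toxic of the three in this test. The change swaps a brominated thiophene ring for an open chain without a ring that carries a hydrogen-bond donor, but nothing measured here explains why the number rises.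

The compounds shown leave open whether the hydroxyl matters or the loss of the ring is enough, a question that a plain 1,1-dimethylpropyl group, or an amine or a carboxylic acid in place of the hydroxyl, would help to settle. As far as these compounds go, it also remains open whether a longer or shorter chain on this nitrogen would give a similar number.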